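Three limits and a biphenyl: compound 4 in view

This account rests on a few compounds, and the source may have more. Where it says the series, first, only, none or still open, it means among the compounds named here.

The series shares one core, carried in compound 1 `COC(=O)[C@H](CCSC)NC(=O)c1ccc(NCc2cncn2Cc2ccc(C)cc2)cc1-c1ccccc1`, compound 2 `COC(=O)[C@H](CCSC)NC(=O)c1ccc(NCc2cncn2Cc2ccc(C#N)cc2)cc1-c1ccccc1` and compound 3 `COC(=O)[C@H](CCSC)NC(=O)c1ccc(NCc2cncn2Cc2ccccc2C#N)cc1-c1ccccc1`. In a functional assay on NIH3T3 cells (Mus musculus) (on this read-out lower numbers stand for an effect already at smaller amounts and higher numbers for an effect only at larger amounts of compound), compound 1 reaches only the limit of the assay, > 10 uM. In this assay compound 2 likewise gives only a limit, > 10 uM. Compound 3 stands at the same limit in this assay, > 10 uM, so no number places it among the others. The steps a step that the two limits leave unreadable from compound 1 to compound 2, a step that the two limits leave unreadable from compound 1 to compound 3 and a step that the two limits leave unreadable from compound 2 to compound 3 carry no readable size, because of the limit of > 10 uM in this assay, at which 3 of the 3 values shown sit. Compound 4 `COC(=O)[C@H](CCSC)NC(=O)c1ccc(NCc2cncn2Cc2ccc(-c3ccccc3)cc2)cc1-c1ccccc1` differs from compound 3 by 4-phenylphenyl in place of 2-cyanophenyl on a saturated chain carbon bound to an aromatic nitrogen. Among the compounds with values here, no measured step speaks to this change, and the three limits show neither a direction nor a size for it. Compound 4 is therefore expected to sit near the same limit, with the step that the limit leaves unreadable from compound 3 to compound 4 estimated as no change beyond the scatter. For compound 4 the expected value in this assay is 20 uM, in a range from 5 uM to 80 uM.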

Compound 4, concentration for half-maximal effect: > 10 uM
Compound 4 gave a limit, no number (the forecaster's own chance of this, stated with the estimate: 80%); the middle value lies beyond the limit too.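

No step from compound 1, compound 2 or compound 3 to compound 4 can be read, because each of these compounds gives only a limit: the limit of > 10 uM in this assay, at which 4 of the 4 values shown sit. The compounds shown leave open which of these changes, if any, moves the read-out in this assay, and in which direction.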